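Chloro in place of methyl on compound 2

This account rests on a few compounds, and the source may have more. Where it says the series, first, only, none or still open, it means among the compounds named here.

In an ADME assay on the whole organism for pharmacokinetics, with Mus musculus as the target, at a dose of 10 mg/kg by the oral route (on this read-out higher numbers stand for higher exposure at the dose given and lower numbers for lower exposure), compound 2 (`CC/C(=C(/c1ccc(/C=C/C(=O)O)cc1)c1ccc2[nH]ncc2c1)c1ccncc1C`) stands lowest with 81 ng.h/mL and compound 1 (`CC/C(=C(/c1ccc(/C=C/C(=O)O)cc1)c1ccc2[nH]ncc2c1)c1cccc(Cl)c1`) gives the higher 11000 ng.h/mL of the two numbers. Compound 3 (`CC/C(=C(/c1ccc(/C=C/C(=O)O)cc1)c1ccc2[nH]ncc2c1)c1ccncc1Cl`) carries chloro in place of methyl on an aromatic carbon. Among the measured compounds shown here, only one measured step bears on this change, and only in part: the large step beyond the scatter (a 140-fold lower number from compound 1 to compound 2 (2.13 log units; beyond the scatter)) puts 3-methylpyridin-4-yl in place of 3-chlorophenyl. A moderate rise is therefore expected, with the estimated step (a 4.9-fold higher number from compound 2 to compound 3 (0.69 log units; beyond the scatter)) recovering only a part of that drop. Compound 3 is estimated at 400 ng.h/mL (expected range 80 ng.h/mL to 2500 ng.h/mL).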

Compound 3, area under the concentration-time curve: 110 ng.h/mL
Compound 3: middle estimate off by 3.6-fold (0.56 log units), on the high side; the measured number falls inside the stated range.
By their numbers in this assay, from the lowest: compounds 2 and 3 (each within the scatter of the next); then compound 1.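

In this assay, chloro in place of methyl on this aromatic carbon, two atoms from the ring nitrogen, gives a 1.4-fold higher number from compound 2 to compound 3 (0.13 log units; within the scatter), so the two groups are not told apart here. With chloro present on both sides, 3-chloropyridin-4-yl in place of 3-chlorophenyl still gives a 100-fold lower number from compound 1 to compound 3 (2.00 log units; beyond the scatter), which ties the large drop to that ring change and not to the methyl. Nothing measured here explains the drop.

As far as these compounds go, whether a methoxy or an amine on this carbon would lift the number remains open. So does whether any group here could recover the level of compound 1.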